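Fluoro in Place of Methoxy: an Expected Small Step

The source may hold more compounds than are shown below. What is called first, only, known or untested is meant among the compounds shown, and "the series" means these compounds.

Measured so far:
Compound 1, `CC1=CC[C@H](C(C)(C)NC(=S)NN)CC1`
Compound 2, `COc1ccc(/C=N/NC(=S)NC(C)(C)[C@H]2CC=C(C)CC2)cc1`

In a functional assay on 786-0 cells (Homo sapiens) for inhibition, read by sulforhodamine B assay, with a stated time of 48 h (a lower number here means a stronger inhibitor of growth, a higher number a weaker inhibitor of growth), compound 1 gives no number but only a limit, > 100000 nM. In this assay compound 2 gives 29600 nM. Among the compounds with values here, that makes compound 2 the only compound with a number here; the other value sits at the limit of > 100000 nM in this assay, at which 1 of the 2 values shown sits, so there is no measured step from one number to another against which a new change could be set.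

Compound 3, `CC1=CC[C@H](C(C)(C)NC(=S)N/N=C/c2ccc(F)cc2)CC1`, is not yet measured. It differs from compound 2 in one place: fluoro in place of methoxy on an aromatic carbon.

Within the data shown here, with no measured step of this kind available, the expectation can rest only on the size of the change, which is small, and on the value of compound 2 in this assay, 29600 nM. The step is expected to be a 1.0-fold higher number from compound 2 to compound 3 (0.01 log units; within the scatter), no more than the usual scatter in either direction. For compound 3 the estimate in this assay is 30000 nM, with a range from 10000 nM to 100000 nM.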

Compound 3, concentration for total growth inhibition: > 100000 nM
Compound 3 gave a limit, no number (the forecaster's own chance of this, stated with the estimate: 15%); middle value at least 3.3-fold (0.52 log units) from the limit.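

In this assay compound 3 gives > 100000 nM, which is a limit and not a number. Within the data shown here, this supplies the first measured step at this place on the ring: the change from 4-methoxyphenyl to 4-fluorophenyl, small as it looks on paper, gives an at least 3.3-fold higher number from compound 2 to compound 3 (0.52 log units; beyond the scatter), so the identity of the group para to a large group matters in this assay, even though the activity of compound 2 is itself weak. Only one end of the step is a number, so it fixes a smallest possible size and no true size, and most of the series shown gives no number to compare: the limit of > 100000 nM in this assay, at which 2 of the 3 values shown sit.

The compounds shown leave open whether the methoxy group is special here or whether other groups at the same place, such as hydroxy, ethoxy, methyl or dimethylamino, would also keep a measurable value. They also leave open how far compound 3 truly lies from compound 2, and what property of the two groups underlies the difference between them.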